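The compounds below may be only part of what the source reports. "The series", "measured", "known", "first", "only" and "open" are said of these compounds alone.

In a functional assay on IMR-32 cells (Homo sapiens) for inhibition, read by sulforhodamine B assay, with a stated time of 48 h (on this read-out lower numbers stand for stronger inhibition of growth and higher numbers for weaker inhibition of growth), compound 1, with the structure `O=C(N/N=C/C1=C(Cl)c2ccccc2CCC1)c1ccccc1`, gives 16100 nM. Compound 2, with the structure `Cc1ccc(C(=O)N/N=C/C2=C(Cl)c3ccccc3CCC2)cc1`, differs from it by a single change, (methyl in place of hydrogen on an aromatic carbon), and in this assay compound 2 gives 300 nM. The step this change made is a 54-fold lower number from compound 1 to compound 2 (1.73 log units; beyond the scatter).

Compound 3, with the structure `Cc1cc2c(cc1C)C(Cl)=C(/C=N/NC(=O)c1ccccc1)CCC2`, carries the same benzohydrazide end as compound 1 but a different core; the difference between the two cores is not broken down here. In this assay compound 3 gives 1800 nM, which places it between the other two, closer to compound 2 than to compound 1.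

Compound 4, with the structure `Cc1ccc(C(=O)N/N=C/C2=C(Cl)c3cc(C)c(C)cc3CCC2)cc1`, has not yet been measured. It stands to compound 3 as compound 2 stands to compound 1: the change is methyl in place of hydrogen on an aromatic carbon, and the place of the change reads the same way in both pairs, so it is the same change on a different core. The step from compound 1 to compound 2 was large, and one pair gives no assurance that a second core will answer in the same measure, so a smaller step is taken as the more probable outcome. The step expected from compound 3 to compound 4 is a 15-fold lower number from compound 3 to compound 4 (1.18 log units; beyond the scatter). That expectation rests on the value of compound 3, 1800 nM, and on the step of a 54-fold lower number from compound 1 to compound 2 (1.73 log units; beyond the scatter). In this assay compound 4 is therefore estimated at 120 nM, within the range 30 nM to 500 nM.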

Compound 4, concentration for 50% growth inhibition: 100 nM
The estimate for compound 4 lay 1.2-fold (0.08 log units) above the measured number; the range from low to high includes it.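

On the core of compound 3, the change from phenyl to 4-methylphenyl again gives a large step in this assay, an 18-fold lower number from compound 3 to compound 4 (1.26 log units; beyond the scatter), so across these two pairs the methyl lowers the number in the same direction. The size of the step does not carry over unchanged, however, and the two cores answer to different extents: the same change on two cores in this assay, a 54-fold lower number (1.73 log units; beyond the scatter) from compound 1 to compound 2 and an 18-fold lower number (1.26 log units; beyond the scatter) from compound 3 to compound 4, 3.0-fold (0.47 log units) apart, beyond the scatter of two such steps. The two pairs thus show that the direction of the step held on both cores and that the step stayed large on each, but they do not give a size that could be applied to another core, they do not explain why the two steps differ, and they do not show that the change would act the same way on a third core.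

The compounds shown leave open whether an ethyl group, a longer chain, a methoxy group, an amine or a carboxylic acid in the place of this methyl would give a similar step on either core. They also leave open which part of the difference between the two cores goes with the smaller step, and whether the chlorine, which all four compounds carry, has any bearing on the result.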